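Ester chain length and tolerated concentration in the series

A few compounds are considered here, and "the series" means these few. Any claim that something is new, unique, unknown or untested is made for them only; others in the source may bear on it.

Going by the values given here, compound 3 `CCCCCOC(=O)C(O)Cn1cnc2c(N)ncnc21` is the only member with a number in a functional assay on PRK cells (Oryctolagus cuniculus) for cytotoxicity; a higher number here means that more compound is tolerated, a lower number that less compound is tolerated; compound 3 gives 200 ug/mL. Compound 1 `CC(C)OC(=O)C(O)Cn1cnc2c(N)ncnc21` stands at a limit of the assay, > 400 ug/mL. Compound 2 `COC(=O)C(O)Cn1cnc2c(N)ncnc21` likewise stands at a limit, > 400 ug/mL. The steps of an at least 2.0-fold lower number from compound 1 to compound 3 (0.30 log units; that floor lies within the scatter) and an at least 2.0-fold lower number from compound 2 to compound 3 (0.30 log units; that floor lies within the scatter) both lengthen the ester chain and both lower the number, whereas a step that the two limits leave unreadable from compound 1 to compound 2. Compound 4 `CCCOC(=O)C(O)Cn1cnc2c(N)ncnc21` differs from compound 3 by hydrogen in place of ethyl on a saturated chain carbon, three bonds along the chain from an oxygen next to a carbonyl group, read one bond further out as pentyl to propyl, a shortening of that chain. Running against the two lengthening steps, compound 4 is expected to show the step of a 2.0-fold higher number from compound 3 to compound 4 (0.30 log units; within the scatter). The number may again reach the assay ceiling, given (the limit of > 400 ug/mL in this assay, at which 2 of the 3 values shown sit). The estimate for compound 4 is 400 ug/mL, within 200 ug/mL to 800 ug/mL.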

Compound 4, minimum cytotoxic concentration: 100 ug/mL
Estimate against measurement, compound 4: 4.0-fold (0.60 log units) above; measured number outside the range, below it.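

Shortening pentyl to propyl does not bring the number back towards the ceiling: a 2.0-fold lower number from compound 3 to compound 4 (0.30 log units; within the scatter), so in this assay these two straight chains are not told apart. Propyl is, however, separated from the shorter methyl ester and from the branched isopropyl ester of the same series by an at least 4.0-fold lower number from compound 2 to compound 4 (0.60 log units; beyond the scatter) and an at least 4.0-fold lower number from compound 1 to compound 4 (0.60 log units; beyond the scatter), so the straight propyl ester already carries the drop. Both sizes are floors: the limit of > 400 ug/mL in this assay, at which 2 of the 4 values shown sit.

Open, going by these compounds, is where an ethyl or butyl ester would stand. On these data alone, a hexyl ester and the free carboxylic acid also remain open.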